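Cyclohexyl in place of pyridin-4-yl: working notes

The source may report more compounds than this note shows. Statements on the series, on what has been measured and on what is new or still open speak of the compounds shown alone.

compound 1 `Nc1nc(-c2ccccc2)nn1-c1ncnc2ccccc12`: > 50000 nM (a limit)
compound 2 `COc1ccc2ncnc(-n3nc(-c4ccccn4)nc3N)c2c1`: > 27000 nM (a limit)
compound 3 `COc1cc2ncnc(-n3nc(-c4ccncc4)nc3N)c2cc1OC`: "not determined" (no result reported)
compound 4 `COc1cc2ncnc(-n3nc(C4CCCCC4)nc3N)c2cc1OC`: not yet measured

The read-out for the series is an ADME assay on BJ cells (Homo sapiens) for cytotoxicity, with a stated time of 72 h; on this read-out higher numbers stand for an effect only at larger amounts of compound and lower numbers for an effect already at smaller amounts. In this assay compound 3 has no number, and its entry reads "not determined" (no result reported). Its place can therefore only be judged from the two other entries, and neither of them is a number. Compound 1 gives > 50000 nM, which is a limit of the assay. Compound 2 gives > 27000 nM, which is also a limit of the assay.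

The change under study is cyclohexyl in place of pyridin-4-yl on an aromatic carbon. It sits on an aromatic carbon of a five-membered aromatic ring with 3 nitrogen, and the shared core stays as it is. Within the data shown here, no measured pair differs in one place, so the size of this step has no direct precedent. The expectation in this assay is a step no larger than the scatter, with no direction preferred, and a good chance that compound 4 also returns only a limit. For compound 4 the estimated value is 30000 nM, with an expected range of 10000 nM to 60000 nM.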

Compound 4, half-maximal effective concentration: > 27000 nM
Compound 4: a limit, no number; the forecaster's own chance of this, stated with the estimate: 65%; the middle value does not contradict the limit.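

In this assay compound 4 gives > 27000 nM, which is a limit of the assay. Compound 3 has no number, so no step can be read between compound 3 and compound 4. The compounds shown leave open whether cyclohexyl in place of pyridin-4-yl shifts the read-out at all, and at what concentration any of them reaches a half-maximal effect.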